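Iodo for methylsulfanyl on the core of compound 3

The source may report more compounds than this note shows. Statements on the series, on what has been measured and on what is new or still open speak of the compounds shown alone.

The series shares one core, seen in compound 1 `COc1cccc(Sc2c(NS(=O)(=O)c3ccc(C(C)(C)C)cc3)noc2CCCCC=O)c1`. In an assay on A7R5 cells for displacement of a labelled ligand from Endothelin-1 receptor (Rattus norvegicus) (a higher number here means a weaker inhibitor, a lower number a stronger inhibitor), compound 1 gives 1400 nM. Compound 2 `COc1cccc(Sc2c(NS(=O)(=O)c3ccc(C(C)(C)C)cc3)noc2C)c1` gives 530 nM in this assay, and the step of a 2.6-fold lower number from compound 1 to compound 2 (0.42 log units; beyond the scatter) is modest. Compound 3 `CSc1c(NS(=O)(=O)c2ccc(C(C)(C)C)cc2)noc1C` reaches only a limit of this assay, > 100000 nM, so its standing is a limit rather than a number (the limit of > 100000 nM in this assay, at which 1 of the 3 values shown sits). The step of an at least 180-fold higher number from compound 2 to compound 3 (2.27 log units; beyond the scatter) is large, a small group on the sulfur in place of 3-methoxyphenyl removing measurable binding.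

Compound 4 `Cc1onc(NS(=O)(=O)c2ccc(C(C)(C)C)cc2)c1I` differs from compound 3 by iodo in place of methylsulfanyl on an aromatic carbon. Among the compounds with values here, only the step from compound 2 to compound 3 bears on this position, and it shows that a single small group there, in place of 3-methoxyphenyl, gives no measurable binding. Iodo is again one heavy atom without a ring, so no recovery is expected in this assay, and the estimate for compound 4 is 100000 nM, within 20000 nM to 500000 nM, most likely again reported as a limit. The expected step from compound 3 to compound 4 is a number no higher from compound 3 to compound 4 (the limit leaves the size open), no change beyond the scatter.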

Compound 4, half-maximal inhibitory concentration: > 100000 nM
Compound 4 was reported as a limit; the forecaster's own chance of this, stated with the estimate: 70%; the middle value lies on the limit itself.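

Iodo in place of (3-methoxyphenyl)sulfanyl gives an at least 180-fold higher number from compound 2 to compound 4 (2.27 log units; beyond the scatter), so a second group without a ring, this one without sulfur, also ends at a limit in this assay. Within the compounds shown, a measurable value at this position occurs only with the (3-methoxyphenyl)sulfanyl group of compound 1 and compound 2. Compound 3 and compound 4 are both reported as limits, so the step between them cannot be read and the two groups cannot be ordered: the limit of > 100000 nM in this assay, at which 2 of the 4 values shown sit.

Still open, from the compounds shown here alone, is which part of the (3-methoxyphenyl)sulfanyl group a measurable value depends on, the sulfur, the ring or the methoxy group. A phenyl group set directly on this aromatic carbon, or an unsubstituted phenylsulfanyl group, would separate these parts.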